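The source may hold more compounds than are shown below. What is called first, only, known or untested is meant among the compounds shown, and "the series" means these compounds.

Of the compounds shown here, three have been measured in an assay for inhibition of protein disulfide-isomerase (Homo sapiens), with a stated time of 1 h; on this read-out higher numbers stand for weaker inhibition and lower numbers for stronger inhibition. Compound 1 `Oc1c(C(c2ccc(F)cc2)N2CCCCC2)ccc2c1OCCO2` gives 290 nM there; compound 2 `Cc1cc(C)c(C(Nc2ccccn2)c2ccc3cccnc3c2O)c(C)c1` gives 190 nM in this assay; compound 3 `Cc1ccnc(NC(c2cccc(F)c2)c2ccc3cccnc3c2O)c1` gives 350 nM in this assay. Compound 2 sits at the low end of the three numbers, but compound 1 and compound 3 both lie within the usual scatter of it, so no ordering among the three is established.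

Compound 4 `Oc1c(C(Nc2ccccn2)c2ccccc2Cl)ccc2cccnc12` has not been measured. It differs from compound 2 at one place: 2-chlorophenyl in place of 2,4,6-trimethylphenyl on a saturated chain carbon bound to an aromatic carbon and a nitrogen on an aromatic ring. Going by the values given here, no single-change pair among the measured compounds matches this exchange, so nothing measured speaks directly to its size. Compound 2 gives 190 nM in this assay, and compound 3, which carries a different group at the same saturated chain carbon and also a different nitrogen ring, gives 350 nM in this assay; that gap is within the scatter. On that basis the step from compound 2 to compound 4 is expected to be small, a 1.6-fold higher number from compound 2 to compound 4 (0.20 log units; within the scatter), with no direction beyond the scatter clearly indicated. Compound 4 is estimated at 300 nM in this assay, within a range of 120 nM to 800 nM.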

Compound 4, half-maximal inhibitory concentration: 500 nM
Compound 4: middle estimate off by 1.7-fold (0.22 log units), on the low side, within the range that was stated.
By their numbers in this assay, from the lowest: compounds 2, 1, 3 and 4 (each within the scatter of the next, the first and the last beyond it).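

Going by these compounds alone, at the saturated chain carbon bound to an aromatic carbon and a nitrogen on an aromatic ring, 2-chlorophenyl in place of 2,4,6-trimethylphenyl gives the first single-place step: in this assay the change is a 2.6-fold higher number from compound 2 to compound 4 (0.42 log units; beyond the scatter) and lies beyond the scatter. The aryl group at this position can therefore move the number, although this single pair sets no trend across aryl groups. No measured evidence is available to explain the step.

The step leaves open whether it tracks the loss of the methyl groups or the gain of the chlorine, a question that a plain phenyl or a 2-methylphenyl at this carbon would help to separate. Also open, going by these compounds, is how this position responds to a non-aromatic group such as cyclohexyl.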